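The source may report more compounds than this note shows. Statements on the series, on what has been measured and on what is new or still open speak of the compounds shown alone.

Measured in a functional assay on the whole organism (strain Kunming) with Mus musculus as the target, in the formalin test, with a stated time of 0.5 h; on this read-out higher numbers stand for an effect only at larger amounts of compound and lower numbers for an effect already at smaller amounts:
- compound 1 `COc1cc(OC)c(OC)cc1/C=C/COC(=O)/C=C/c1ccc(Br)cc1`: 243 umol/kg
- compound 2 `COc1cccc(/C=C/C(=O)OC/C=C/c2cc(OC)c(OC)cc2OC)c1`: > 260 umol/kg (a limit of the assay)

Compound 2 has no exact number in this assay, only a limit: the limit of > 260 umol/kg in this assay, at which 1 of the 2 values shown sits. Compound 3 `COc1cc(OC)c(OC)cc1/C=C/COC(=O)/C=C/c1ccc(Cl)cc1` has not yet been measured. The change from compound 2 is 4-chlorophenyl in place of 3-methoxyphenyl on a double-bonded chain carbon bound to a double-bonded chain carbon.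

Among the compounds with values here, one measured step bears on this place: an at least 1.0-fold higher number from compound 1 to compound 2 (0.02 log units; that floor lies within the scatter), with 3-methoxyphenyl in place of 4-bromophenyl. Going by these compounds, that step ends on a limit and its floor lies within the scatter, so its true size remains open. Compound 3 loses the same 3-methoxyphenyl, and what enters is 4-chlorophenyl rather than 4-bromophenyl. The closest guide is therefore compound 1, which gives 243 umol/kg in this assay. Within the data shown here, no chlorine-bearing compound has been measured, so this reading rests on compound 1 alone.

The estimated step is an at least 1.1-fold lower number from compound 2 to compound 3 (0.07 log units; that floor lies within the scatter), expected to lean toward a lower number without clearly leaving the scatter. For compound 3 the expected value is 220 umol/kg. The estimated range for compound 3 runs from 110 umol/kg to 420 umol/kg.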

Compound 3, dose for half-maximal effect: 278 umol/kg
Beside the measured number, compound 3's estimate is 1.3-fold (0.10 log units) below it; the range from low to high includes it.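

Within the data shown here, the new pair gives the first readable comparison at this position: with chloro in place of bromo on an aromatic carbon, the result in this assay is a 1.1-fold higher number from compound 1 to compound 3 (0.06 log units; within the scatter). Compound 1 and compound 3 therefore cannot be told apart on this read-out, so exchanging one of these two halogens for the other on the aromatic carbon makes no difference that stands out from the scatter. The step from compound 2 to compound 3 cannot be read, because compound 2 has only a limit and not a number: the limit of > 260 umol/kg in this assay, at which 1 of the 3 values shown sits.

How 4-chlorophenyl truly compares with 3-methoxyphenyl on the double-bonded chain carbon therefore stays open, and the compounds shown cannot say whether the methoxy group or its place on the ring matters here. Also open, going by these compounds, is whether fluoro or iodo on the aromatic carbon would stay within the scatter of chloro and bromo, and what an amine or a carboxylic acid on that phenyl ring would do in this assay.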